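Amide cap of the enone series: propyl in place of dichlorophenyl

A few compounds are considered here, and "the series" means these few. Any claim that something is new, unique, unknown or untested is made for them only; others in the source may bear on it.

Three amide caps on the shared core have been measured. In a functional assay on HUVEC cells (Homo sapiens) for inhibition, tested at 10 ug/mL (a higher number here means a stronger effect of the compound at the concentration tested, a lower number a weaker effect), compound 1 `COc1cc(/C=C/C(=O)c2cccc(NC(=O)c3cccs3)c2)ccc1O` gives 90%, compound 3 `COc1cc(/C=C/C(=O)c2cccc(NC(=O)c3ccco3)c2)ccc1O` gives 100%, and compound 2 `COc1cc(/C=C/C(=O)c2cccc(NC(=O)c3cc(Cl)cc(Cl)c3)c2)ccc1O` gives 58%, the lowest of the three. The two steps away from it are large: a number 42 percentage points higher from compound 2 to compound 3 (beyond the scatter), and in the reverse sense a number 32 percentage points lower from compound 1 to compound 2 (beyond the scatter). Compound 4 `CCCC(=O)Nc1cccc(C(=O)/C=C/c2ccc(O)c(OC)c2)c1` carries the change (propyl in place of 3,5-dichlorophenyl on a carbonyl carbon). Among the compounds with values here, no measured step trades the dichlorophenyl for a chain without a ring, so the measured steps bear only indirectly; both show that the dichlorophenyl cap sits well under the others. A rise beyond the scatter is therefore expected for compound 4, of about a number 17 percentage points higher from compound 2 to compound 4 (beyond the scatter), to an estimated 75% with a range of 45% to 100%.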

Compound 4, a percentage reported as inhibition, at one concentration (the size of the read-out at that concentration, not a potency): 87%
For compound 4 the middle estimate is 12 percentage points below the measured one; the range from low to high includes it.
By their numbers in this assay, from the lowest: compound 2; then compounds 4, 1 and 3 (each within the scatter of the next, the first and the last beyond it).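

The change gives a number 29 percentage points higher from compound 2 to compound 4 (beyond the scatter) in this assay, so a high number at this position does not require a ring on the carbonyl carbon. Propyl shows a number 3 percentage points lower from compound 1 to compound 4 (within the scatter) and a number 13 percentage points lower from compound 3 to compound 4 (beyond the scatter), placing it level with the thiophen-2-yl cap but under the furan-2-yl cap. Having a ring or not therefore does not sort these four caps, as compound 1, compound 2 and compound 3 all carry one.

Nothing available explains these differences. Still open, from the compounds shown here alone, is how a longer chain such as pentyl, an unsubstituted phenyl cap or a chain ending in an amine or a carboxylic acid would read.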